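The source may hold more compounds than are shown below. What is called first, only, known or untested is meant among the compounds shown, and "the series" means these compounds.

Compound 1 `CC(C)CNc1nc(/C=C/c2ccccc2)nc2ccsc12`: > 1000000 nM
Compound 2 `CCN1CCN(c2nc(/C=C/c3cc(OC)c(OC)c(OC)c3)nc3ccsc23)CC1`: > 1000000 nM

In a functional assay on L02 cells (Homo sapiens) for inhibition, read by Griess assay, with stated times of 1 h and 24 h (on this read-out lower numbers stand for stronger inhibition and higher numbers for weaker inhibition), compound 1 gives > 1000000 nM, which is a limit of the assay rather than a number. In this assay compound 2 gives > 1000000 nM, also a limit. Compound 2 thus stands at the limit of > 1000000 nM in this assay, at which 2 of the 2 values shown sit. Compound 3 `COc1cc(/C=C/c2nc(NCc3ccncc3)c3sccc3n2)cc(OC)c1OC` differs from compound 2 in one place: ((pyridin-4-yl)methyl)amino in place of 4-ethylpiperazin-1-yl on an aromatic carbon. Going by the values given here, no measured step guides this change, so no shift beyond the usual scatter is expected, and the change is estimated at a step that the limit leaves unreadable from compound 2 to compound 3. Compound 3 is therefore expected to give about 1500000 nM, most likely within 200000 nM to 10000000 nM.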

Compound 3, half-maximal inhibitory concentration: 374000 nM
For compound 3 the middle estimate is 4.0-fold (0.60 log units) above the measured one; the range from low to high includes it.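

In this assay, going by these compounds alone, compound 3 gives 374000 nM, the first value here that is a number rather than a limit, so this position on the shared core can respond to a change of group. Placing ((pyridin-4-yl)methyl)amino in place of 4-ethylpiperazin-1-yl gives an at least 2.6-fold lower number from compound 2 to compound 3 (0.42 log units; beyond the scatter). This size is only a minimum because compound 2 gives a limit: the limit of > 1000000 nM in this assay, at which 2 of the 3 values shown sit.

The compounds shown do not separate the effect of the pyridine ring from that of the amino hydrogen, which enter together. As far as these compounds go, how a benzylamino or a morpholin-4-yl group would read at this position stays open.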